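The compounds below may be only part of what the source reports. "The series", "measured", "known", "first", "only" and "open" are said of these compounds alone.

Working notes on the series in a functional assay on GLC82 cells (Homo sapiens) for cytotoxicity, read by MTT assay, with a stated time of 72 h; a lower number here means a stronger inhibitor, a higher number a weaker inhibitor. Compound 1 `COc1cc2ncnc(NNC(=S)NC(=O)c3ccccc3C)c2cc1OC` gives 21500 nM. Compound 2 `Cc1ccc(C(=O)NC(=S)NNc2ncnc3ccccc23)cc1` gives 11200 nM, the lowest of the two numbers, though the gap to compound 1 lies within the scatter, so no order between them is claimed. Compound 3 `O=C(NC(=S)NNc1ncnc2ccccc12)c1ccc(F)cc1` is the next to be measured. The change from compound 2 is fluoro in place of methyl on an aromatic carbon. Within the data shown here, no measured pair carries this change, so the step is expected to be small, in no particular direction, and not beyond the scatter, as a 1.1-fold higher number from compound 2 to compound 3 (0.03 log units; within the scatter). For compound 3 the estimate is 12000 nM, within 5000 nM to 30000 nM.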

Compound 3, half-maximal inhibitory concentration: 6070 nM
The estimate for compound 3 lay 2.0-fold (0.30 log units) above the measured number, and the stated range covers the measured number.
By their numbers in this assay, from the lowest: compounds 3, 2 and 1 (each within the scatter of the next, the first and the last beyond it).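

Among these compounds, the first measured pair at this position, 4-methylphenyl to 4-fluorophenyl, gives in this assay a 1.8-fold lower number from compound 2 to compound 3 (0.27 log units; within the scatter) and so stays within the scatter. Fluoro in place of methyl on this aromatic carbon therefore shows no clear effect on the number, and one pair sets no trend. Nothing measured here accounts for the size of this step.

As far as these compounds go, whether a chloro, a methoxy, an amine or a carboxylic acid at this place would give a step beyond the scatter stays open. Also open, from the compounds shown here alone, is whether the same change would read alike on the core of compound 1.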